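Swapping ethyl for 2-methylphenyl on a well-tolerated amide

The source may report more compounds than this note shows. Statements on the series, on what has been measured and on what is new or still open speak of the compounds shown alone.

In a toxicity assay on THP-1 cells (Homo sapiens) for inhibition (a lower number here means that less compound is tolerated, a higher number that more compound is tolerated), compound 2 (`CCC(=O)Nc1ncc(-c2ccc(OC)cc2)n1C`) gives > 100000 nM and this value is a limit of the assay. Compound 3 (`COc1ccc(-c2cnc(NC(=O)c3ccccc3C)n2C)cc1`) carries 2-methylphenyl in place of ethyl on a carbonyl carbon. Among the measured compounds shown here, no measured pair shows this change, so the expectation leans on compound 1 (`Cn1c(-c2ccccc2Cl)cnc1NC(=O)c1ccc(F)cc1`), whose > 50000 nM is also a limit. The expected change is an at least 1.6-fold lower number from compound 2 to compound 3 (0.22 log units; that floor lies within the scatter) in this assay and it points modestly towards less compound tolerated. Compound 3 is estimated at 60000 nM with 20000 nM to 100000 nM as the expected range.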

Compound 3, half-maximal cytotoxic concentration: > 100000 nM
Compound 3 gave a limit, no number; the forecaster's own chance of this, stated with the estimate: 70%; middle value at least 1.6-fold (0.22 log units) away from the limit.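

Compound 2 and compound 3 both stop at a limit of this assay, so the step between them cannot be read. On these data alone, whether 2-methylphenyl in place of ethyl changes tolerance at all stays open.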